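Swapping the amide tail of compound 1 for a thiophene

The compounds below may be only part of what the source reports. "The series", "measured", "known", "first", "only" and "open" are said of these compounds alone.

Measured compounds:
compound 1 `CC(=O)N1CCC(C(=O)NCCCNc2nc(Nc3cccc(F)c3)ncc2Br)CC1` — 430 nM
compound 2 `O=C(NCCCNc1nc(Nc2cnn(C3CC3)c2)ncc1C1CC1)C1CCC1` — 10 nM
compound 3 `O=C(NCCCNc1nc(Nc2cnn(C3CCOCC3)c2)ncc1C1CC1)C1CCC1` — 2 nM

In an assay on isolated protein for inhibition of serine/threonine-protein kinase TBK1 (Homo sapiens) (a higher number here means a weaker inhibitor, a lower number a stronger inhibitor), compound 1 gives 430 nM, the highest number of the three. Compound 2, which differs from it in several places at once, gives 10 nM, and compound 3 gives 2 nM, so compound 1 sits clearly apart from both.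

Within the data shown here, the only single-point step among the measured compounds is a 5.0-fold lower number from compound 2 to compound 3 (0.70 log units; beyond the scatter), a change on the aromatic nitrogen far from the amide end of the molecule.

Compound 4 `O=C(NCCCNc1nc(Nc2cccc(F)c2)ncc1Br)c1cccs1` is formed from compound 1 by the change (thiophen-2-yl in place of 1-acetylpiperidin-4-yl on a carbonyl carbon). Among the measured compounds shown here, no measured step touches this carbonyl carbon, so nothing in the data says how this assay responds to what sits on the amide. The shared core of compound 1, which carries the bromine and the fluorinated aniline, is kept unchanged in compound 4, and that part of the molecule is what separates compound 1 from compounds 2 and 3.

For the measured compounds named here, with no guiding step, the expectation for compound 4 is anchored on compound 1, where the value 430 nM was recorded, with a wide range in either direction: compound 4 is estimated at 400 nM (from 100 nM to 1600 nM), an expected step of a 1.1-fold lower number from compound 1 to compound 4 (0.03 log units; within the scatter).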

Compound 4, half-maximal inhibitory concentration: 9 nM
The estimate for compound 4 lay 44-fold (1.65 log units) above the measured number, outside the stated range (below it).
By their numbers in this assay, from the lowest: compound 3; then compounds 4 and 2 (each within the scatter of the next); then compound 1.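

In this assay, among these compounds, thiophen-2-yl in place of 1-acetylpiperidin-4-yl on a carbonyl carbon gives a 48-fold lower number from compound 1 to compound 4 (1.68 log units; beyond the scatter), so the group at this place, which no earlier step touched, has a large bearing on the read-out. The rest of compound 1 stays unchanged in this step, so the whole difference belongs to this one swap, in which a group of 9 heavy atoms with a six-membered non-aromatic ring gives way to one of 5 heavy atoms with a five-membered aromatic ring. Nothing available explains why this swap has so large an effect.

The compounds shown leave open whether the difference comes from the presence of the thiophene or from the loss of the 1-acetylpiperidin-4-yl group, a question that a phenyl ring, a furan-2-yl ring or a piperidin-4-yl group without its acetyl on this carbonyl carbon could help to settle. They also leave open whether thiophen-2-yl would give a step of similar size on the core of compound 2, which differs from the core of compound 1 in several places.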